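Chain Length and Inhibition Across Two Related Cores

The compounds below may be only part of what the source reports. "The series", "measured", "known", "first", "only" and "open" are said of these compounds alone.

Compound 1 `CC(C)c1cc(-c2n[nH]c(=O)n2-c2cccc(C(=O)NCCCCCC(=O)NO)c2)c(O)cc1O` and compound 2 `CC(C)c1cc(-c2n[nH]c(=O)n2-c2cccc(C(=O)NCCCC(=O)NO)c2)c(O)cc1O` share one core and differ only in the length of the chain that carries the hydroxamic acid. In a functional assay on A549 cells (Homo sapiens) for inhibition (on this read-out higher numbers stand for weaker inhibition and lower numbers for stronger inhibition), compound 1 gives 4600 nM, and compound 2 gives 4600 nM. The step of no change at the digits printed from compound 1 to compound 2 (within the scatter) corresponds to hydroxycarbamoyl in place of 2-(hydroxycarbamoyl)ethyl on a saturated chain carbon, three bonds along the chain from an amide-type nitrogen.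

Compound 3 `CC(C)c1cc(-c2n[nH]c(=O)n2-c2ccc(C(=O)NCCCCCCCC(=O)NO)cc2)c(O)cc1O` is built on a second core; the difference between the two cores is not broken down here. In this assay compound 3 gives 4600 nM, level with compounds 1 and 2.

Compound 4 `CC(C)c1cc(-c2n[nH]c(=O)n2-c2ccc(C(=O)NCCCCCC(=O)NO)cc2)c(O)cc1O` has not yet been measured. It differs from compound 3 by hydroxycarbamoyl in place of 2-(hydroxycarbamoyl)ethyl on a saturated chain carbon, five bonds along the chain from an amide-type nitrogen, the same kind of change as before, though the place now lies five bonds along the chain from an amide-type nitrogen rather than three. Because the step of no change at the digits printed from compound 1 to compound 2 (within the scatter) stayed within the scatter, compound 4 is expected to follow compound 3 with a step of no change at the digits printed from compound 3 to compound 4 (within the scatter). Compound 4 is therefore estimated at 4600 nM, most likely between 2300 nM and 9200 nM.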

Compound 4, half-maximal inhibitory concentration: 4600 nM
For compound 4 middle estimate and measured number coincide at the digits printed; measured number inside the range.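

The change of 2-(hydroxycarbamoyl)ethyl to hydroxycarbamoyl gives no change at the digits printed from compound 3 to compound 4 (within the scatter) in this assay, and it gives the same result on the other core: the same change on two cores in this assay, no change at the digits printed (within the scatter) from compound 1 to compound 2 and no change at the digits printed (within the scatter) from compound 3 to compound 4, 1.0-fold (0.00 log units) apart, within the scatter of two such steps

For these two pairs, then, the change carries from one core to the other with the same outcome. This does not show that the same would hold on a further core or at other chain lengths, and as neither step exceeds the scatter, it says nothing about whether a larger effect would carry over.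

The compounds shown leave open how a carboxylic acid in place of the hydroxamic acid would behave on either core. They also leave open what a chain longer than that of compound 3 would give.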